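Cyano in place of formyl on the chromene core

The source may hold more compounds than are shown below. What is called first, only, known or untested is meant among the compounds shown, and "the series" means these compounds.

Measured compounds:
Compound 1, `CC1(C)C=C(n2ccccc2=O)c2ccccc2O1`: 5.05
Compound 2, `CC1(C)C=C(n2ccccc2=O)c2cc(C(=O)c3cccs3)ccc2O1`: 5.84
Compound 3, `CC1(C)C=C(n2ccccc2=O)c2cc(C=O)ccc2O1`: 6.14

Three compounds share one core and differ only in the group on an aromatic carbon of the six-membered carbon ring. In a functional assay (trachea) with Rattus norvegicus as the target (on this read-out higher numbers stand for higher potency (the scale is a negative logarithm) and lower numbers for lower potency), compound 1 gives 5.05, compound 2 gives 5.84, and compound 3 gives 6.14. Compound 3 stands highest of the three numbers, yet its nearest neighbour is compound 2, which lies within the scatter of it, so the two cannot be ordered; only compound 1 lies clearly lower.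

Compound 4, `CC1(C)C=C(n2ccccc2=O)c2cc(C#N)ccc2O1`, has not been measured. It differs from compound 3 in one place: cyano in place of formyl on an aromatic carbon.

Among the compounds with values here, the steps that bear on this change are a number 1.09 log units higher from compound 1 to compound 3 (beyond the scatter) and a number 0.79 log units higher from compound 1 to compound 2 (beyond the scatter), which show that a small carbonyl-bearing group at this position raises the number, and a number 0.30 log units higher from compound 2 to compound 3 (within the scatter), which shows that the size of the group on the carbonyl carbon hardly matters. Cyano, like formyl, carries one acceptor on two heavy atoms, so compound 4 is expected to stay close to compound 3, with a number 0.14 log units lower from compound 3 to compound 4 (within the scatter) judged within the scatter. Compound 4 is therefore estimated at 6, between 5.4 and 6.6.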

Compound 4, logarithm of the reciprocal of the active concentration, log(1/C): 7.1
The estimate for compound 4 lay 1.10 log units below the measured number; measured number outside the range, above it.
By their numbers in this assay, from the lowest: compound 1; then compounds 2 and 3 (each within the scatter of the next); then compound 4.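

In this assay, cyano in place of formyl gives a number 0.96 log units higher from compound 3 to compound 4 (beyond the scatter), so these two groups are not interchangeable on this aromatic carbon, even though they match in heavy atoms, hydrogen-bond donors and hydrogen-bond acceptors. The same group gives a number 1.26 log units higher from compound 2 to compound 4 (beyond the scatter) and a number 2.05 log units higher from compound 1 to compound 4 (beyond the scatter), which sets compound 4 apart from all three earlier compounds and shows that a carbonyl is not required for a high number at this position. Nothing in the data given accounts for the difference between cyano and formyl here.

The compounds shown leave open whether the rise is particular to cyano or would also appear with other groups on this aromatic carbon, such as nitro, trifluoromethyl, an amine or a carboxylic acid. Within the data shown here, they also leave open whether cyano would give a similar step on another carbon of the same ring, or with a different group in place of the one that all four compounds share on the other ring of the core.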